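From 1,3-thiazol-2-yl to pyridazin-3-yl on a Sulfonamide Nitrogen

The source may report more compounds than this note shows. Statements on the series, on what has been measured and on what is new or still open speak of the compounds shown alone.

Among the measured compounds shown here, in a physicochemical assay for solubility (a lower number here means a less soluble compound, a higher number a more soluble compound), three compounds have numbers so far. Compound 2 `Cn1nccc1-c1cc(C(F)(F)F)ccc1[C@H]1CCOc2cc(S(=O)(=O)Nc3nccs3)ccc21` stands second highest at 83000 nM and so lies in the middle (compound 1 `CN1CCN(c2cc(C(F)(F)F)ccc2[C@H]2CCOc3cc(S(=O)(=O)Nc4nccs4)ccc32)CC1` gives 176000 nM and compound 3 `O=S(=O)(Nc1nccs1)c1ccc2c(c1)OCC[C@@H]2c1ccc(C(F)(F)F)cc1-c1ccc(F)cc1` gives 39000 nM).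

The next molecule, compound 4 `Cn1nccc1-c1cc(C(F)(F)F)ccc1[C@H]1CCOc2cc(S(=O)(=O)Nc3cccnn3)ccc21`, differs from compound 2 at one place: pyridazin-3-yl in place of 1,3-thiazol-2-yl on a sulfonamide nitrogen. For the measured compounds named here, no measured step touches that place. All three swap a group on an aromatic carbon instead, so they offer only a rough sense of size, with a 2.1-fold lower number from compound 1 to compound 2 (0.33 log units; beyond the scatter) in one case, a 2.1-fold lower number from compound 2 to compound 3 (0.33 log units; beyond the scatter) in another and a 4.5-fold lower number from compound 1 to compound 3 (0.65 log units; beyond the scatter) in a third. They give no direction for this new swap, so a modest step at most is expected, and it could fall within the usual scatter. The estimated step is a 1.2-fold higher number from compound 2 to compound 4 (0.08 log units; within the scatter) for this change. Compound 4 is estimated at 100000 nM with an expected range from 35000 nM to 280000 nM in this assay readings.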

Compound 4, solubility: 915000 nM
Beside the measured number, compound 4's estimate is 9.2-fold (0.96 log units) below it; measured number above the stated range.
By their numbers in this assay, from the lowest: compound 3; then compound 2; then compound 1; then compound 4.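

In this assay the group on the sulfonamide nitrogen carries more weight than any change seen so far on the aromatic carbon: an 11-fold higher number from compound 2 to compound 4 (1.04 log units; beyond the scatter) is a larger move than a 4.5-fold lower number from compound 1 to compound 3 (0.65 log units; beyond the scatter) in the earlier series. The swap leaves the counted hydrogen-bond donors, hydrogen-bond acceptors and net charge unchanged, so those counts do not separate the two groups, while the ring goes from five-membered to six-membered and the sulfur drops out. Among the compounds shown here, nothing available here explains why this swap moves the number so far.

On these data alone, this step rests on a single pair, so it remains open whether pyridazin-3-yl would give a similar rise alongside 4-methylpiperazin-1-yl or 4-fluorophenyl. As far as these compounds go, how other groups on the sulfonamide nitrogen, such as a pyridin-2-yl ring or a simple methyl, would compare also remains open.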